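Furan for benzofuran on two nucleoside cores

The source may report more compounds than this note shows. Statements on the series, on what has been measured and on what is new or still open speak of the compounds shown alone.

Measured compounds:
compound 2 `Cc1nc(N)c2c(-c3cc4ccccc4o3)cn([C@@H]3O[C@H](CO)[C@@H](O)[C@H]3O)c2n1` — 15700 nM
compound 1 `Cc1nc(N)c2c(-c3ccco3)cn([C@@H]3O[C@H](CO)[C@@H](O)[C@H]3O)c2n1` — > 20000 nM
compound 3 `CNc1ncnc2c1c(-c1cc3ccccc3o1)cn2[C@@H]1O[C@H](CO)[C@@H](O)[C@H]1O` — > 20000 nM

In a functional assay on K562 cells (Homo sapiens), read by MTT assay, with a stated time of 72 h (a higher number here means a weaker inhibitor, a lower number a stronger inhibitor), compound 2 gives 15700 nM. For compound 1 the assay reports only a limit, > 20000 nM. The change from compound 2 to compound 1 is furan-2-yl in place of 1-benzofuran-2-yl on an aromatic carbon and produced an at least 1.2-fold higher number from compound 2 to compound 1 (0.10 log units; that floor lies within the scatter), so no direction can be read from this pair.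

Compound 3 sits on a different core; the difference between the two cores is not broken down here. For compound 3 the assay reports only a limit, > 20000 nM.

Compound 4 `CNc1ncnc2c1c(-c1ccco1)cn2[C@@H]1O[C@H](CO)[C@@H](O)[C@H]1O` has not been measured. It arises from compound 3 by furan-2-yl in place of 1-benzofuran-2-yl on an aromatic carbon, the same change as from compound 2 to compound 1. The expectation for compound 4 rests on compound 3 already giving only the limit > 20000 nM, and on (the limit of > 20000 nM in this assay, at which 2 of the 3 values shown sit), which two of three compounds reach. A step that the limit leaves unreadable from compound 3 to compound 4 is expected, with a limit the most likely outcome. Compound 4 is therefore estimated at 30000 nM, between 15000 nM and 70000 nM.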

Compound 4, half-maximal inhibitory concentration: 220 nM
Estimate against measurement, compound 4: 140-fold (2.13 log units) above; the whole stated range lies above it.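

In this assay, furan-2-yl in place of 1-benzofuran-2-yl on the core of compound 3 produces an at least 90-fold lower number from compound 3 to compound 4 (1.95 log units; beyond the scatter), a large step beyond the scatter. On the two cores shown, the same change does not carry over with the same size: the same change on two cores in this assay, an at least 1.2-fold higher number (0.10 log units; that floor lies within the scatter) from compound 2 to compound 1 and an at least 90-fold lower number (1.95 log units; beyond the scatter) from compound 3 to compound 4, at least 110-fold (2.06 log units) apart, beyond the scatter of two such steps. This shows that the outcome of the change depends on the core in these two pairs, but compound 1 and compound 3 each carry only a limit, so neither step has a known true size, and one pair per core cannot establish a rule for the series.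

Open is which of the differences between the two cores governs the step, since the compounds shown do not vary those differences one at a time. Also open, as far as these compounds go, is how a thiophen-2-yl ring or a small amine on the same aromatic carbon would behave on the core of compound 4 in this assay.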